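A few compounds are considered here, and "the series" means these few. Any claim that something is new, unique, unknown or untested is made for them only; others in the source may bear on it.

Measured in a functional assay on MGC-803 cells (Homo sapiens) for inhibition, read by MTT assay, with a stated time of 48 h; a lower number here means a stronger inhibitor, a higher number a weaker inhibitor:

- Compound 1 `C/C=C/C(=O)N(Cc1ccc(OC)c([N+](=O)[O-])c1)c1cc(OC)c(OC)c(OC)c1`: 590 nM
- Compound 2 `C/C=C/C(=O)N(Cc1ccc(OC)c(N)c1)c1cc(OC)c(OC)c(OC)c1`: 150 nM
- Compound 3 `C/C=C/C(=O)N(Cc1ccc(OC)c(O)c1)c1cc(OC)c(OC)c(OC)c1`: 27 nM

These compounds share a core and differ in a single group. Compound 3 has the lowest number of the three, and its steps to both others lie beyond the scatter, which makes it the strongest inhibitor so far.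

The next compound, compound 4 `C/C=C/C(=O)N(Cc1ccc(OC)c(Cl)c1)c1cc(OC)c(OC)c(OC)c1`, has chloro in place of hydroxy on an aromatic carbon, ortho to a methoxy group: chloro in place of hydroxy on an aromatic carbon. The change reads 3-hydroxy-4-methoxyphenyl to 3-chloro-4-methoxyphenyl.

Going by the values given here, no compound with chloro in this place has been measured, so the evidence is indirect. The relevant steps are those at the same place: a 22-fold lower number from compound 1 to compound 3 (1.34 log units; beyond the scatter) and a 5.6-fold lower number from compound 2 to compound 3 (0.74 log units; beyond the scatter). The step of a 3.9-fold lower number from compound 1 to compound 2 (0.59 log units; beyond the scatter) shows that the two groups other than hydroxy also differ from each other. Among the compounds with values here, both groups gave a higher number than hydroxy, so losing hydroxy is expected to cost activity here too, though only three groups have been compared. A modest to large rise is therefore expected in this assay.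

The expected change is a 6.7-fold higher number from compound 3 to compound 4 (0.82 log units; beyond the scatter). Compound 4 is estimated at 180 nM, within a range of 45 nM to 700 nM.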

Compound 4, half-maximal inhibitory concentration: 7100 nM
Estimate against measurement, compound 4: 39-fold (1.60 log units) below; the measured number lies above the stated range.
By their numbers in this assay, from the lowest: compound 3; then compound 2; then compound 1; then compound 4.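

In this assay, chloro proves the poorest of the four groups tried at this place on the ring, giving a 260-fold higher number from compound 3 to compound 4 (2.42 log units; beyond the scatter) and also a 47-fold higher number from compound 2 to compound 4 (1.68 log units; beyond the scatter). Even nitro, previously the worst group, does better, as chloro gives a 12-fold higher number from compound 1 to compound 4 (1.08 log units; beyond the scatter), so compound 4 is the weakest inhibitor of the four and the place is far more sensitive to its substituent than the first three compounds revealed. The counts show that hydroxy carries a hydrogen-bond donor and acceptor while chloro carries neither, but no measurement here explains why activity falls so steeply.

The four compounds cannot separate the loss of hydroxy from the arrival of chloro, and a plain hydrogen at this place would help to make that distinction. Fluoro, bromo and methyl would show whether chloro is an isolated poor choice or one of a wider set of groups that perform badly here, while a hydroxymethyl group would test whether the hydroxy must sit directly on the ring.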